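Dichloro step on the phenol series, carried to the aniline core

The compounds below may be only part of what the source reports. "The series", "measured", "known", "first", "only" and "open" are said of these compounds alone.

Compound 1 `C=C[C@@](C)(/C=C/c1ccc(O)c(/C=C/c2ccc(Cl)cc2)c1)CCC=C(C)C` and compound 2 `C=C[C@@](C)(/C=C/c1ccc(O)c(/C=C/c2ccc(Cl)c(Cl)c2)c1)CCC=C(C)C` share a phenol core and differ by chloro in place of hydrogen on an aromatic carbon. In a functional assay on NALM-6 cells (Homo sapiens) for cytotoxicity, with a stated time of 72 h (a lower number here means that less compound is needed, a higher number that more compound is needed for the effect), compound 1 reaches only the limit > 43400 nM. Compound 2 gives 7510 nM in this assay, so the step is an at least 5.7-fold lower number from compound 1 to compound 2 (0.76 log units; beyond the scatter). The size of that step is bounded on one side by the limit of > 43400 nM in this assay, at which 2 of the 3 values shown sit. Compound 3 `C=C[C@@](C)(/C=C/c1ccc(Nc2ccc(Cl)cc2)cc1)CCC=C(C)C` carries an aniline core instead of the phenol; the difference between the two cores is not broken down here. In this assay compound 3 also sits at the limit > 43400 nM. Compound 4 `C=C[C@@](C)(/C=C/c1ccc(Nc2ccc(Cl)c(Cl)c2)cc1)CCC=C(C)C` is the not yet measured partner of compound 3 and differs from it by chloro in place of hydrogen on an aromatic carbon, the same change as between compound 1 and compound 2, at the same place by every word given. Carrying the step seen on the phenol core over to the aniline core, the expected step is an at least 3.6-fold lower number from compound 3 to compound 4 (0.55 log units; beyond the scatter), resting on compound 2 at 7510 nM. For compound 4 the estimate is accordingly 12000 nM, between 4000 nM and 43400 nM, with a fair chance that only a limit is returned.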

Compound 4, half-maximal effective concentration: > 43400 nM
Compound 4: only a limit was reported; the forecaster's own chance of this, stated with the estimate: 45%; middle value at least 3.6-fold (0.55 log units) away from the limit.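

In this assay, compound 3 and compound 4 both stop at a limit, so no step can be read between them: the limit of > 43400 nM in this assay, at which 3 of the 4 values shown sit.

The compounds shown leave open whether chloro in place of hydrogen on an aromatic carbon changes the number at all on the core of compound 3, as it does on the core of compound 1.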